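Phenyl-to-pyridinyl swap on the triazole of compound 1

The compounds below may be only part of what the source reports. "The series", "measured", "known", "first", "only" and "open" are said of these compounds alone.

Going by the values given here, in a functional assay on MCF7 cells (Homo sapiens) for cytotoxicity, read by MTT assay, with a stated time of 48 h (on this read-out higher numbers stand for weaker inhibition and lower numbers for stronger inhibition), compound 1 `CC(C)=CCC/C(C)=C/CC/C(C)=C/CC[C@@H]1[C@@]2(C)CC/C(=N\OCc3cn(-c4ccccc4)nn3)C(C)(C)[C@@H]2CC[C@@]1(C)O` gives 9590 nM, the lowest of the three numbers measured so far. Compound 2 `COc1cccc(-n2cc(CO/N=C3\CC[C@]4(C)[C@@H](CC/C=C(\C)CC/C=C(\C)CCC=C(C)C)[C@](C)(O)CC[C@H]4C3(C)C)nn2)c1` gives 25400 nM in this assay, and compound 3 `CC(C)=CCC/C(C)=C/CC/C(C)=C/CC[C@@H]1[C@@]2(C)CC/C(=N\OCc3cn(-c4ccccc4C#N)nn3)C(C)(C)[C@@H]2CC[C@@]1(C)O` gives 24900 nM. Both changes to the ring on the triazole nitrogen raised the number: a 2.6-fold higher number from compound 1 to compound 2 (0.42 log units; beyond the scatter), and a 2.6-fold higher number from compound 1 to compound 3 (0.41 log units; beyond the scatter). Between the two substituted compounds the gap is small, a 1.0-fold lower number from compound 2 to compound 3 (0.01 log units; within the scatter).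

Compound 4 `CC(C)=CCC/C(C)=C/CC/C(C)=C/CC[C@@H]1[C@@]2(C)CC/C(=N\OCc3cn(-c4ccncc4)nn3)C(C)(C)[C@@H]2CC[C@@]1(C)O` differs from compound 1 only in the ring on the triazole nitrogen: pyridin-4-yl in place of phenyl on an aromatic nitrogen. Among the compounds with values here, no measured step exchanges one ring for another of the same size; the two measured steps from compound 1 only add a group to the phenyl, and both were modest. A step of similar or smaller size is therefore expected, in the direction of a higher number, though a step within the scatter cannot be excluded. The expected step is a 1.7-fold higher number from compound 1 to compound 4 (0.22 log units; within the scatter). For compound 4 the estimate in this assay is 16000 nM, with a range from 6000 nM to 40000 nM.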

Compound 4, half-maximal inhibitory concentration: 12600 nM
Compound 4: middle estimate off by 1.3-fold (0.10 log units), on the high side, within the range that was stated.
By their numbers in this assay, from the lowest: compounds 1, 4, 3 and 2 (each within the scatter of the next, the first and the last beyond it).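

In this assay, exchanging the ring itself on the aromatic nitrogen, rather than adding methoxy or cyano to the phenyl, gives a 1.3-fold higher number from compound 1 to compound 4 (0.12 log units; within the scatter), so this position accepts pyridin-4-yl, with its ring nitrogen and one hydrogen-bond acceptor, without a step beyond the scatter. Compound 4 also stays within the scatter of both substituted compounds, with a 2.0-fold lower number from compound 3 to compound 4 (0.30 log units; within the scatter) and a 2.0-fold lower number from compound 2 to compound 4 (0.30 log units; within the scatter), so it is not separated from either side of the gap that divides compound 1 from compound 2 and compound 3. No data on hand account for this result.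

Open, from the compounds shown here alone, is how pyridin-2-yl or pyridin-3-yl would read here, which would show whether the place of the ring nitrogen matters. Also open, going by these compounds, is whether an amine or a carboxylic acid on the phenyl, or a butyl chain in place of the ring, would hold the number.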